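The source may report more compounds than this note shows. Statements on the series, on what has been measured and on what is new or still open speak of the compounds shown alone.

In a functional assay on A549 cells (Homo sapiens) for antiproliferative activity, read by MTT assay (a lower number here means a stronger inhibitor, a higher number a weaker inhibitor), three compounds with a shared core have been measured: compound 1 (`CC1(C)CCc2cc(C(=O)/C=C/c3ccc(OCc4cn(-c5ccc(Br)cc5)nn4)cc3)c(O)cc2O1`) gives 80000 nM, compound 2 (`COc1ccc(-n2cc(COc3ccc(/C=C/C(=O)c4cc5c(cc4O)OC(C)(C)CC5)cc3)nn2)c([N+](=O)[O-])c1`) gives 99500 nM, and compound 3 (`Cc1ccc(-n2cc(COc3ccc(/C=C/C(=O)c4cc5c(cc4O)OC(C)(C)CC5)cc3)nn2)cc1Br`) gives 125000 nM. Compound 3 therefore stands level with the other two, since none of the values separates beyond the scatter.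

Compound 4 (`CC1(C)CCc2cc(C(=O)/C=C/c3ccc(OCc4cn(Cc5ccc([N+](=O)[O-])cc5)nn4)cc3)c(O)cc2O1`) keeps the core and differs from compound 3 in one place, with 4-nitrobenzyl in place of 3-bromo-4-methylphenyl on an aromatic nitrogen.

Among the compounds with values here, three measured steps bear on this position, and each exchanges one substituted phenyl for another: a 1.2-fold higher number from compound 1 to compound 2 (0.09 log units; within the scatter), a 1.6-fold higher number from compound 1 to compound 3 (0.19 log units; within the scatter) and a 1.3-fold higher number from compound 2 to compound 3 (0.10 log units; within the scatter). Within the data shown here, no measured compound carries a benzyl group on that nitrogen, so this part of the change is untested, and the range must stay wide. A nitro group does appear in the 4-methoxy-2-nitrophenyl of compound 2, at 99500 nM, but there it sits on a phenyl attached directly to the nitrogen.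

On these steps, no change beyond the scatter is expected in this assay. The expected step is a 1.3-fold lower number from compound 3 to compound 4 (0.10 log units; within the scatter). For compound 4 the estimate is 100000 nM, with an expected range from 40000 nM to 220000 nM.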

Compound 4, half-maximal inhibitory concentration: 35800 nM
Beside the measured number, compound 4's estimate is 2.8-fold (0.45 log units) above it, and the stated range ends above it.
By their numbers in this assay, from the lowest: compound 4; then compounds 1, 2 and 3 (each within the scatter of the next).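

In this assay, 4-nitrobenzyl on the aromatic nitrogen gives the first differences at this position that lie beyond the scatter, all of them modest: a 3.5-fold lower number from compound 3 to compound 4 (0.54 log units; beyond the scatter), a 2.8-fold lower number from compound 2 to compound 4 (0.44 log units; beyond the scatter) and a 2.2-fold lower number from compound 1 to compound 4 (0.35 log units; beyond the scatter). The position therefore does respond to a change of group, which the three substituted phenyl groups of compounds 1, 2 and 3 had not shown, and a nitro group on a phenyl attached directly to the nitrogen, as in compound 2, does not set that compound apart from compounds 1 and 3. Nothing given here accounts for the difference.

Compound 4 changes both the link to the nitrogen and the substituents on the ring, so the compounds shown leave open whether the benzyl carbon, the nitro group or the two together carry the step. A plain benzyl group on the same nitrogen would separate these, while a longer chain bearing the same ring, or an amine in place of the nitro group, would show how far the trend extends.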